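Swapping chloro for hydroxy on compound 2

The compounds below may be only part of what the source reports. "The series", "measured", "known", "first", "only" and "open" are said of these compounds alone.

- compound 1 `COc1cccc(/C=C2\CCC/C(=C\c3cccc(Cl)c3)C2=O)c1OC`: 9100 nM
- compound 2 `COc1cccc(/C=C2\CCC/C(=C\c3ccc(O)c(Cl)c3)C2=O)c1OC`: 16800 nM

In a functional assay on SW-620 cells (Homo sapiens) for cytotoxicity, read by MTT assay, with a stated time of 72 h (a higher number here means a weaker inhibitor, a lower number a stronger inhibitor), compound 2 at 16800 nM lies within the usual scatter of compound 1. Compound 3 `COc1cccc(/C=C2\CCC/C(=C\c3ccc(O)c(O)c3)C2=O)c1OC` differs from compound 2 by hydroxy in place of chloro on an aromatic carbon, with hydroxy in place of chloro on an aromatic carbon: 3-chloro-4-hydroxyphenyl becomes 3,4-dihydroxyphenyl. Among the compounds with values here, the one measured step that bears on this, a 1.8-fold higher number from compound 1 to compound 2 (0.27 log units; within the scatter), put hydroxy in place of hydrogen, so it is only a loose guide. No change beyond the scatter is expected, and the expected step is a 1.2-fold lower number from compound 2 to compound 3 (0.08 log units; within the scatter). For compound 3 the estimate is 14000 nM, within an expected range of 5000 nM to 40000 nM.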

Compound 3, half-maximal inhibitory concentration: 6300 nM
Compound 3: the middle estimate sits 2.2-fold (0.35 log units) above what was measured; the range from low to high includes it.
By their numbers in this assay, from the lowest: compounds 3, 1 and 2 (each within the scatter of the next, the first and the last beyond it).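

In this assay, within the data shown here, the change from 3-chloro-4-hydroxyphenyl to 3,4-dihydroxyphenyl gives a 2.7-fold lower number from compound 2 to compound 3 (0.43 log units; beyond the scatter) as the first step here beyond the scatter, so what sits at this place on the ring does matter, if only modestly. Replacing 3-chlorophenyl with 3,4-dihydroxyphenyl gives a 1.4-fold lower number from compound 1 to compound 3 (0.16 log units; within the scatter) and thus no real separation between those two compounds. No available evidence accounts for the step.

Open, as far as these compounds go, is how an amine or a carboxylic acid would behave at this place. The compounds also leave open whether the step holds on other cell lines.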